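Chloro for Fluoro on a Diaryl Ether Tetrazole

The compounds below may be only part of what the source reports. "The series", "measured", "known", "first", "only" and "open" are said of these compounds alone.

Of the compounds shown here, two have been measured in an assay on microsomes from brain for inhibition of Fatty-acid amide hydrolase 1 (Rattus norvegicus), read by fluorescence and HPLC, with a stated time of 60 min; on this read-out lower numbers stand for stronger inhibition and higher numbers for weaker inhibition. Compound 1 `COC(=O)c1ccc(-c2nnn(CC(=O)C(C)Oc3ccc(Oc4ccc(Cl)cc4)cc3)n2)cc1` gives 47 nM. Compound 2 `CC(Oc1ccc(Oc2ccc(F)cc2)cc1)C(=O)Cn1nnc(-c2ccc(C(=O)O)cc2)n1` gives 100 nM, the higher of the two numbers and beyond the usual scatter from compound 1, so compound 2 stands as the weaker inhibitor of the pair so far.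

Compound 3 `CC(Oc1ccc(Oc2ccc(Cl)cc2)cc1)C(=O)Cn1nnc(-c2ccc(C(=O)O)cc2)n1` has not yet been measured. It differs from compound 2 in a single way: chloro in place of fluoro on an aromatic carbon. The change is small, a single heavy atom swapped for another of the same kind on an aromatic carbon, and nothing else in the shared core moves.

Because compound 1, which carries the chloro group, gives 47 nM, a step towards a somewhat lower number seems reasonable to expect, though it may well fall within the scatter; the expected step is a 1.5-fold lower number from compound 2 to compound 3 (0.19 log units; within the scatter). The estimate for compound 3 in this assay is 65 nM, with a range from 25 nM to 170 nM.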

Compound 3, half-maximal inhibitory concentration: 90 nM
The estimate for compound 3 lay 1.4-fold (0.14 log units) below the measured number; low and high end bracket the measured number.
By their numbers in this assay, from the lowest: compounds 1, 3 and 2 (each within the scatter of the next, the first and the last beyond it).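

In this assay, chloro in place of fluoro on this aromatic carbon, para to a large group, gives a 1.1-fold lower number from compound 2 to compound 3 (0.05 log units; within the scatter), so with the acid end held fixed, this swap of one halogen for the other produces no difference that can be read. Compound 3 also allows a direct comparison of hydrogen with the methyl of the ester, and a 1.9-fold higher number from compound 1 to compound 3 (0.28 log units; within the scatter) shows that this change also stays within what repeated measurements can separate. Nothing available here explains why either change leaves so little mark.

Still open, from the compounds shown here alone, is whether a different group on this aromatic carbon, such as bromo, methoxy or nitrile, would shift the number beyond the scatter. Going by these compounds, it is also open whether an amide at the other end of the molecule, in place of the ester or the acid, would behave in the same way.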